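A few compounds are considered here, and "the series" means these few. Any claim that something is new, unique, unknown or untested is made for them only; others in the source may bear on it.

Working notes on a small set of quinolone acids measured in an assay on isolated protein for inhibition of DNA topoisomerase 1 (Homo sapiens), with a stated time of 15 min; a lower number here means a stronger inhibitor, a higher number a weaker inhibitor.

Compound 1 `CN[C@@H]1CCN(c2cc3c(cc2F)c(=O)c(C(=O)O)cn3Cc2ccc(-c3ccccc3)cc2)C1` gives 34800 nM in this assay. Compound 2 `CN[C@@H]1CCN(c2c(F)cc3c(=O)c(C(=O)O)cn(Cc4ccc(-c5ccccc5)cc4)c3c2OC)C1` differs from compound 1 by methoxy in place of hydrogen on an aromatic carbon; in this assay compound 2 gives 57700 nM, and the step is a 1.7-fold higher number from compound 1 to compound 2 (0.22 log units; within the scatter), so the two values cannot be ordered against each other.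

Compound 3 `NC[C@@H]1CCN(c2cc3c(cc2F)c(=O)c(C(=O)O)cn3Cc2ccc(-c3ccc(F)cc3)cc2)C1` carries a different core, and the difference between the core of compound 3 and the core of compound 1 is not broken down here. In this assay compound 3 gives 69600 nM, which lies within the scatter of both compound 1 and compound 2, so no ranking among the three measured compounds is supported.

Compound 4 `COc1c(N2CC[C@@H](CN)C2)c(F)cc2c(=O)c(C(=O)O)cn(Cc3ccc(-c4ccc(F)cc4)cc3)c12` is not yet measured. It differs from compound 3 by methoxy in place of hydrogen on an aromatic carbon. This is the same kind of change as that from compound 1 to compound 2, not the same change: in compound 4 the methoxy sits ortho to a 3-(aminomethyl)pyrrolidin-1-yl group, whereas in compound 2 it sits ortho to a 3-(methylamino)pyrrolidin-1-yl group; the other surroundings of the place are the same.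

The expectation for compound 4 rests on one precedent, the step of a 1.7-fold higher number from compound 1 to compound 2 (0.22 log units; within the scatter), which is itself within the scatter. For compound 4 a step of a 1.6-fold higher number from compound 3 to compound 4 (0.20 log units; within the scatter) is expected in this assay, leaving the compound at the weak end of the set. The estimated value for compound 4 in this assay is 110000 nM, with a range from 50000 nM to 250000 nM.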

Compound 4, half-maximal inhibitory concentration: 60900 nM
Estimate against measurement, compound 4: 1.8-fold (0.26 log units) above; measured number inside the range.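

In this assay, methoxy in place of hydrogen on an aromatic carbon gives a 1.1-fold lower number from compound 3 to compound 4 (0.06 log units; within the scatter), so compound 3 and compound 4 cannot be ordered against each other. Set beside the earlier step, the same change shows no readable difference between the two cores: the same change on two cores in this assay, a 1.7-fold higher number (0.22 log units; within the scatter) from compound 1 to compound 2 and a 1.1-fold lower number (0.06 log units; within the scatter) from compound 3 to compound 4, 1.9-fold (0.28 log units) apart, within the scatter of two such steps. Within the data shown here, this shows only that neither core, one carrying the 3-(methylamino)pyrrolidin-1-yl group and the other the 3-(aminomethyl)pyrrolidin-1-yl group, gives a step that stands clear of the scatter; it does not show that methoxy is without influence, nor that the change behaves identically on every core, as two small steps cannot establish either claim.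

The compounds shown leave open whether a different group on this aromatic carbon, such as chloro, ethoxy or an amine, would give a step beyond the scatter in this assay. They also leave open whether a primary amide in place of the carboxylic acid would give a readable step, on either core.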